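The source may report more compounds than this note shows. Statements on the series, on what has been measured and on what is new or still open speak of the compounds shown alone.

In an ADME assay on microsomes from liver (Homo sapiens) for metabolic stability, read by LC-MS, with NADPH named in the record, with a stated time of 60 min, in the absence of a further agent (on this read-out higher numbers stand for fast clearance and lower numbers for slow clearance), compound 1 `CCCCc1ccc(-c2nc(C)c(/C(C)=N/NC(=N)N)s2)cc1` gives 0.5 mL.min-1.g-1. Compound 2 `CCCCOc1ccc(-c2nc(C)c(/C(C)=N/NC(=N)N)s2)cc1` is reported only as a limit, < 9.6 mL.min-1.g-1. Among the compounds with values here, the single measured step, a step that the limit leaves unreadable from compound 1 to compound 2, therefore offers no size to carry forward. Compound 3 `CCCCCCOc1ccc(-c2nc(C)c(/C(C)=N/NC(=N)N)s2)cc1` differs from compound 2 by ethyl in place of hydrogen on a saturated chain carbon, four bonds along the chain from an oxygen on an aromatic ring. No readable step bears on this change, so no clear shift in either direction is expected. The estimated step is a step that the limit leaves unreadable from compound 2 to compound 3. In this assay, compound 3 is estimated at 6 mL.min-1.g-1, with an expected range from 1 mL.min-1.g-1 to 20 mL.min-1.g-1.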

Compound 3, intrinsic clearance in microsomes: < 9.6 mL.min-1.g-1
Compound 3 ended at the assay's limit; the forecaster's own chance of this, stated with the estimate: 45%; the middle value is on the limit's open side.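

No step can be read among compound 1, compound 2 and compound 3 in this assay, where compound 2 and compound 3 stand only as limits. The compounds shown leave open whether butoxy and hexyloxy differ in clearance at all.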